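Amide in place of sulfoxide on the shared core

The compounds below may be only part of what the source reports. "The series", "measured", "known", "first", "only" and "open" are said of these compounds alone.

Compound 3 `CC(C)Cn1c(=O)n(C)c(=O)c2nc([S+]([O-])CCCO)c(Cc3cccc4ccccc34)nc21` gives 1990 nM in a functional assay on Raji cells (Homo sapiens) for inhibition, read by MTT assay, with a stated time of 96 h (a lower number here means that less compound is needed, a higher number that more compound is needed for the effect), the lowest of the two numbers available, with compound 2 `CC(C)Cn1c(=O)n(C)c(=O)c2nc(SCCO)c(Cc3cccc4ccccc34)nc21` at 2850 nM sitting within the scatter of it. Compound 1 `CC(C)Cn1c(=O)n(C)c(=O)c2c1nc(Cc1cccc3ccccc13)c(=O)n2CCCCCCO` is recorded only as > 10000 nM, which is the limit of > 10000 nM in this assay, at which 1 of the 3 values shown sits. Among the compounds with values here, the one measured step, a 1.4-fold lower number from compound 2 to compound 3 (0.16 log units; within the scatter), stayed within the scatter. Compound 4 `CC(C)Cn1c(=O)n(C)c(=O)c2nc(C(=O)NCCCO)c(Cc3cccc4ccccc34)nc21` carries the change (a group of 7 heavy atoms (4 carbon, 1 nitrogen, 2 oxygen; no ring) in place of a group of 6 heavy atoms (3 carbon, 2 oxygen, 1 sulfur; no ring), on an aromatic carbon); the group that enters is (3-hydroxypropyl)carbamoyl. Within the data shown here, no measured step exchanges the sulfur chain for the carbamoyl group, and the single step on that chain was within the scatter, so no shift beyond the scatter is expected in this assay. For compound 4 the estimate is 2500 nM, between 800 nM and 8000 nM, an expected step of a 1.3-fold higher number from compound 3 to compound 4 (0.10 log units; within the scatter).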

Compound 4, half-maximal effective concentration: > 10000 nM
Compound 4 ended at the assay's limit (the forecaster's own chance of this, stated with the estimate: 15%); middle value at least 4.0-fold (0.60 log units) away from the limit.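

Within the data shown here, at this aromatic carbon the two sulfur-linked chains stayed within the scatter of each other, and the carbamoyl link is the first change there to go beyond it. In this assay, (3-hydroxypropyl)carbamoyl gives an at least 5.0-fold higher number from compound 3 to compound 4 (0.70 log units; beyond the scatter), and in place of (2-hydroxyethyl)sulfanyl it gives an at least 3.5-fold higher number from compound 2 to compound 4 (0.54 log units; beyond the scatter). The value of compound 4 is a limit and not a number: the limit of > 10000 nM in this assay, at which 2 of the 4 values shown sit.

The compounds shown leave open whether a sulfone, a carboxylic acid or a tertiary amide at this carbon would give a measurable value. On these data alone, a longer chain on the carbamoyl group also remains open.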